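A few compounds are considered here, and "the series" means these few. Any claim that something is new, unique, unknown or untested is made for them only; others in the source may bear on it.

Of the compounds shown here, three built on one shared core have been measured in a functional assay on HT-29 cells (Homo sapiens) for antiproliferative activity, read by MTT assay, with a stated time of 48 h; on this read-out higher numbers stand for weaker inhibition and lower numbers for stronger inhibition. Compound 1 `COc1cc(N/C=C\C(=O)c2cn(-c3ccccc3)nc2-c2ccccc2)cc(OC)c1OC` gives 9800 nM. Going by the values given here, compound 2 `COc1cc(N/C=C\C(=O)c2cn(-c3ccccc3)nc2-c2ccc(Cl)cc2)cc(OC)c1OC` gives 12700 nM; the step of a 1.3-fold higher number from compound 1 to compound 2 (0.11 log units; within the scatter) is the only single change measured so far. Compound 3 `COc1ccc(N/C=C\C(=O)c2cn(-c3ccccc3)nc2-c2cc(OC)c(OC)c(OC)c2)cc1` gives 5780 nM, the lowest of the three numbers, though within the scatter of compound 1 and beyond it only against compound 2. Compound 4 `COc1cc(N/C=C\C(=O)c2cn(-c3ccccc3)nc2-c2cc(OC)c(OC)c(OC)c2)cc(OC)c1OC` carries 3,4,5-trimethoxyphenyl in place of 4-methoxyphenyl on an amine nitrogen. Among the compounds with values here, no measured step touches that part of the molecule; the one step measured concerns a chloro substituent elsewhere, so nothing points in either direction. Compound 4 is therefore expected to sit close to compound 3. The expected step is a 1.0-fold higher number from compound 3 to compound 4 (0.02 log units; within the scatter) in this assay, nothing beyond the scatter. The estimate for compound 4 is 6000 nM, with a range from 2500 nM to 15000 nM.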

Compound 4, half-maximal inhibitory concentration: 8400 nM
Beside the measured number, compound 4's estimate is 1.4-fold (0.15 log units) below it; measured number inside the range.
By their numbers in this assay, from the lowest: compounds 3, 4, 1 and 2 (each within the scatter of the next, the first and the last beyond it).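

In this assay putting 3,4,5-trimethoxyphenyl in place of 4-methoxyphenyl on an amine nitrogen gives a step within the scatter (a 1.5-fold higher number from compound 3 to compound 4 (0.16 log units; within the scatter)), so the added methoxy groups at this place do not separate the two compounds. On an aromatic carbon, 3,4,5-trimethoxyphenyl in place of 4-chlorophenyl (a 1.5-fold lower number from compound 2 to compound 4 (0.18 log units; within the scatter)) or of phenyl (a 1.2-fold lower number from compound 1 to compound 4 (0.07 log units; within the scatter)) also stays within the scatter. Going by these compounds, whether an amine or a carboxylic acid in place of these methoxy groups would move the number beyond the scatter remains open. No evidence is available to explain these numbers.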